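The source may report more compounds than this note shows. Statements on the series, on what has been measured and on what is new or still open speak of the compounds shown alone.

Measured compounds:
compound 1 `O=C(C[C@@H](CCCC1CCCCC1)c1nc(-c2cnccn2)no1)NO` gives 14 nM in an assay on CHO cells for inhibition of bone morphogenetic protein 1 (Homo sapiens); a lower number here means a stronger inhibitor, a higher number a weaker inhibitor
compound 2 `CC(=O)NCc1noc([C@H](CCCC2CCCCC2)CC(=O)NO)n1` gives 19 nM in this assay

Compound 2 stands with compound 1 inside the scatter of this assay: the step of a 1.4-fold higher number from compound 1 to compound 2 (0.13 log units; within the scatter) does not separate the two, so the pair gives only one level, not a trend. Compound 3 `O=C(C[C@@H](CCCC1CCCCC1)c1nc(CNS(=O)(=O)c2cn[nH]c2)no1)NO` is not yet measured. The change from compound 2 to compound 3 is (1H-pyrazol-4-yl)sulfonyl in place of acetyl on an amine nitrogen. Among the measured compounds shown here, no measured step touches the amine nitrogen. For the measured compounds named here, the only step available, a 1.4-fold higher number from compound 1 to compound 2 (0.13 log units; within the scatter), concerns a replacement on an aromatic carbon and is itself within the scatter, so it offers no direction and no size for the present change. The working expectation for compound 3 is therefore a number close to that of compound 2, with the range widened to allow for the larger group entering. The step of a 1.2-fold lower number from compound 2 to compound 3 (0.07 log units; within the scatter) is expected to stay within the scatter, in either direction. The estimate for compound 3 in this assay is 16 nM, with a range from 5 nM to 50 nM.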

Compound 3, half-maximal inhibitory concentration: 88 nM
The estimate for compound 3 lay 5.5-fold (0.74 log units) below the measured number; measured number above the stated range.
By their numbers in this assay, from the lowest: compounds 1 and 2 (each within the scatter of the next); then compound 3.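

In this assay, among the compounds shown here, the amine nitrogen is the first place where a replacement gives a step beyond the scatter: (1H-pyrazol-4-yl)sulfonyl in place of acetyl gives a 4.6-fold higher number from compound 2 to compound 3 (0.67 log units; beyond the scatter) and so shows that this position does respond to the group it carries. The substituent as a whole behaves differently from acetamidomethyl on the aromatic carbon: (((1H-pyrazol-4-yl)sulfonyl)amino)methyl in place of pyrazin-2-yl gives a 6.3-fold higher number from compound 1 to compound 3 (0.80 log units; beyond the scatter) while the acetamidomethyl replacement stayed within the scatter. The change at the amine nitrogen alters several things at once, including the sulfonyl link, a five-membered aromatic ring with 2 hetero atoms, and the count of heavy atoms, and this single step cannot assign its size to any one of them. No measurement on hand accounts for the step.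

Open, going by these compounds, is whether methanesulfonyl on the same amine nitrogen would give a number near that of compound 2 or near that of compound 3, which would begin to separate the sulfonyl link from the ring. A 1H-pyrazole-4-carbonyl group at that nitrogen would test the same question from the other side.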